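A few compounds are considered here, and "the series" means these few. Any claim that something is new, unique, unknown or untested is made for them only; others in the source may bear on it.

Measured so far in a functional assay on HCT-116 cells (Homo sapiens) for inhibition; on this read-out lower numbers stand for stronger inhibition and higher numbers for weaker inhibition:
compound 1 `CCNC(=O)c1noc(-c2cc(C(C)C)c(O)cc2O)c1-c1cc(CN(C)C)no1`: 92 nM
compound 2 `CCCN(CCC)Cc1cc(-c2c(C(=O)NCC)noc2-c2cc(C(C)C)c(O)cc2O)on1`: 183 nM
compound 3 `CCNC(=O)c1noc(-c2cc(C(C)C)c(O)cc2O)c1-c1cc(CN2CCN(C)CC2)no1`: 340 nM

Compound 1 gives the lowest of the three numbers in this assay; the step of a 2.0-fold higher number from compound 1 to compound 2 (0.30 log units; within the scatter) lies within the scatter, while a 3.7-fold higher number from compound 1 to compound 3 (0.57 log units; beyond the scatter) is beyond it, a modest rise. Compound 4 `CCNC(=O)c1noc(-c2cc(C(C)C)c(O)cc2O)c1-c1cnn(C)c1` carries the change (1-methyl-1H-pyrazol-4-yl in place of 3-((dimethylamino)methyl)-1,2-oxazol-5-yl on an aromatic carbon). Among the compounds with values here, the measured steps only exchange one amine for another on the saturated chain carbon bound to an aromatic carbon; none removes that chain and its amine together with the whole ring, so no step bears directly on this change. Given that even the exchange of amines shifted the number modestly, a somewhat larger step is expected here, toward a higher number: a 3.0-fold higher number from compound 1 to compound 4 (0.48 log units; beyond the scatter). For compound 4 the estimate in this assay is 280 nM, with a range from 80 nM to 1000 nM.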

Compound 4, half-maximal inhibitory concentration: 41 nM
Compound 4: the middle estimate sits 6.8-fold (0.83 log units) above what was measured; measured number outside the range, below it.
By their numbers in this assay, from the lowest: compound 4; then compounds 1, 2 and 3 (each within the scatter of the next, the first and the last beyond it).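

At an aromatic carbon of the five-membered aromatic ring with 1 nitrogen and 1 oxygen, 1-methyl-1H-pyrazol-4-yl in place of 3-((dimethylamino)methyl)-1,2-oxazol-5-yl gives a 2.2-fold lower number from compound 1 to compound 4 (0.35 log units; beyond the scatter) in this assay. The amine on the saturated chain is therefore not needed for a low number on this read-out, since compound 4 lacks that chain while compounds 1, 2 and 3 all carry it. No measurement at hand accounts for this step.

Open, on these data alone, is how an unsubstituted 1,2-oxazol-5-yl, or a 1-methyl-1H-pyrazol-4-yl carrying a dimethylaminomethyl chain, would compare, which would separate the exchange of ring from the loss of the amine.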